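The source may report more compounds than this note shows. Statements on the series, on what has been measured and on what is new or still open speak of the compounds shown alone.

Compound 1 `COc1ccc(N/N=C2\CCC(C)n3c2ncc(C(=O)O)c3=O)cc1` gives 7.6 umol/kg in a functional assay on the whole organism for inhibition, with Rattus norvegicus as the target; on this read-out higher numbers stand for an effect only at larger amounts of compound and lower numbers for an effect already at smaller amounts. Compound 2 `CCOc1ccc(N/N=C2\CCC(C)n3c2ncc(C(=O)O)c3=O)cc1` reaches only the limit of this assay, > 100 umol/kg. Compound 3 `Cc1cccc(N/N=C2\CCC(C)n3c2ncc(C(=O)O)c3=O)c1` gives 72.5 umol/kg.

Among the two numbers, compound 3 stands highest; its nearest neighbour is compound 1, set apart by a 9.5-fold higher number from compound 1 to compound 3 (0.98 log units; beyond the scatter). The other measured step, an at least 13-fold higher number from compound 1 to compound 2 (1.11 log units; beyond the scatter), runs up to a limit (the limit of > 100 umol/kg in this assay, at which 1 of the 3 values shown sits). Compound 4 `Cc1ccc(N/N=C2\CCC(C)n3c2ncc(C(=O)O)c3=O)cc1` differs from compound 3 by 4-methylphenyl in place of 3-methylphenyl on an amine nitrogen. Neither measured step shifts only the place of a methyl on the phenyl: the step to compound 3 swapped the whole group, and the step to compound 2 lengthened the chain. Within the data shown here, no step therefore bears directly on this change, and none beyond the scatter is expected in this assay, with a lean toward a lower number because compound 1 with its 4-methoxyphenyl gave 7.6 umol/kg. Compound 4 is expected at 40 umol/kg, within 12 umol/kg to 130 umol/kg. The expected step reads a 1.8-fold lower number from compound 3 to compound 4 (0.26 log units; within the scatter).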

Compound 4, dose for 50% inhibition: > 1000 umol/kg
Compound 4: no number, only a limit; the forecaster's own chance of this, stated with the estimate: 15%; middle value at least 25-fold (1.39 log units) away from the limit.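

Moving the methyl from 3-methylphenyl to 4-methylphenyl on the amine nitrogen, with the same atoms throughout, gives an at least 13-fold higher number from compound 3 to compound 4 (1.13 log units; beyond the scatter) in this assay, so the place of this one methyl counts here. With the group kept in the same place, methyl in place of methoxy gives an at least 130-fold higher number from compound 1 to compound 4 (2.11 log units; beyond the scatter), so the methyl of compound 4 does not stand in for the methoxy of compound 1. Compound 4 has a limit rather than a number: the limit of > 1000 umol/kg in this assay, at which 1 of the 4 values shown sits.

Compound 2 and compound 4 both stand at limits, and the step between them cannot be read. As far as these compounds go, whether 4-chlorophenyl or 3-methoxyphenyl on the amine nitrogen would follow compound 1 or compound 4 stays open.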